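A Smaller Ring on a Fluorinated Urea Core

The source may report more compounds than this note shows. Statements on the series, on what has been measured and on what is new or still open speak of the compounds shown alone.

Three ureas were measured in a physicochemical assay for solubility, read by mass spectrometry, in phosphate buffer, with a stated time of 24 h, at pH 7.4; a higher number here means a more soluble compound, a lower number a less soluble compound. Compound 1 `O=C(Nc1ccc(C(F)(F)F)cc1)NC1CCN(C(=O)C2CCCOC2)CC1` gives 1.1 ug/mL, compound 2 `O=C(Nc1ccc(C(F)(F)F)cc1)NC1CCN(C(=O)[C@@H]2CCOC2)CC1` gives 1.4 ug/mL, and compound 3 `O=C(Nc1ccc(C(F)(F)F)c(F)c1)NC1CCN(C(=O)C2CCCOC2)CC1` gives 11 ug/mL. The change oxolan-3-yl in place of oxan-3-yl on a carbonyl carbon made the step of a 1.3-fold higher number from compound 1 to compound 2 (0.10 log units; within the scatter). The two cores differ by fluoro in place of hydrogen on an aromatic carbon, which made the step of a 10-fold higher number from compound 1 to compound 3 (1.00 log units; beyond the scatter). Compound 4 `O=C(Nc1ccc(C(F)(F)F)c(F)c1)NC1CCN(C(=O)[C@@H]2CCOC2)CC1` is not yet measured; it differs from compound 3 by oxolan-3-yl in place of oxan-3-yl on a carbonyl carbon, the same change as that from compound 1 to compound 2, placed on the core of compound 3. Because the earlier step of a 1.3-fold higher number from compound 1 to compound 2 (0.10 log units; within the scatter) stayed within the scatter, the step from compound 3 to compound 4 in this assay is expected to be small, a 1.2-fold higher number from compound 3 to compound 4 (0.07 log units; within the scatter). Compound 4 is therefore estimated at 13 ug/mL, with a range from 5 ug/mL to 30 ug/mL.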

Compound 4, solubility: 1.9 ug/mL
Beside the measured number, compound 4's estimate is 6.8-fold (0.84 log units) above it; measured number outside the range, below it.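

In this assay, oxolan-3-yl in place of oxan-3-yl gave a 1.3-fold higher number from compound 1 to compound 2 (0.10 log units; within the scatter) on the core of compound 1 but a 5.8-fold lower number from compound 3 to compound 4 (0.76 log units; beyond the scatter) on the core of compound 3, so the change did not carry from one core to the other. Read the other way, fluoro in place of hydrogen on an aromatic carbon gave a 10-fold higher number from compound 1 to compound 3 (1.00 log units; beyond the scatter) with oxan-3-yl but a 1.4-fold higher number from compound 2 to compound 4 (0.13 log units; within the scatter) with oxolan-3-yl, so within these four compounds the two changes do not add. This single set of four compounds shows that the step depends on its partner, but nothing shown accounts for that dependence.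

The compounds shown leave open how an amine, a carboxylic acid or a longer ether chain on that carbonyl would behave on either core. They also leave open whether oxolan-3-yl with the opposite defined stereocentre would match compound 4.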